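Replacing 3,5-dichlorophenyl with 3-bromophenyl: what to expect

This account rests on a few compounds, and the source may have more. Where it says the series, first, only, none or still open, it means among the compounds named here.

Of the compounds shown here, three sharing one core have been measured in a functional assay on SK-BR-3 cells (Homo sapiens) for antiproliferative activity, read by MTT assay, with a stated time of 72 h; a higher number here means a weaker inhibitor, a lower number a stronger inhibitor. Compound 1 `CCN1CCN(c2cc(C)c3cc(NC(=O)c4cccc(Cl)c4)ccc3n2)CC1` gives 17800 nM, compound 2 `CCN1CCN(c2cc(C)c3cc(NC(=O)c4ccccc4F)ccc3n2)CC1` gives 38100 nM, and compound 3 `CCN1CCN(c2cc(C)c3cc(NC(=O)c4cc(Cl)cc(Cl)c4)ccc3n2)CC1` gives 2660 nM. Compound 3 therefore has the lowest number of the three, which makes it the strongest inhibitor so far.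

The next compound to be measured is compound 4 `CCN1CCN(c2cc(C)c3cc(NC(=O)c4cccc(Br)c4)ccc3n2)CC1`, which has 3-bromophenyl in place of 3,5-dichlorophenyl on a carbonyl carbon.

Going by the values given here, two measured steps bear on this change. The closer one is a 6.7-fold lower number from compound 1 to compound 3 (0.83 log units; beyond the scatter), a modest step in which chloro takes the place of hydrogen on an aromatic carbon. The other is a 14-fold lower number from compound 2 to compound 3 (1.16 log units; beyond the scatter), a large step showing that this assay can respond strongly to a change in this aromatic group. Among the compounds with values here, compound 4 resembles compound 1 in carrying a single halogen on the ring, but bromine replaces chlorine, and no measured step shows what that swap does.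

Part of the gain seen in compound 3 is therefore expected to be lost, giving a modest rise in the number. The expected size of this change is a 3.8-fold higher number from compound 3 to compound 4 (0.58 log units; beyond the scatter). The estimated value for compound 4 is 10000 nM, with an expected range from 3500 nM to 25000 nM.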

Compound 4, half-maximal inhibitory concentration: 13300 nM
Compound 4: middle estimate off by 1.3-fold (0.12 log units), on the low side, within the range that was stated.
By their numbers in this assay, from the lowest: compound 3; then compounds 4 and 1 (each within the scatter of the next); then compound 2.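

Swapping chloro for bromo on the single-halogen ring gives a 1.3-fold lower number from compound 1 to compound 4 (0.13 log units; within the scatter) in this assay, so the identity of this one halogen, chlorine or bromine, makes no difference that this assay can resolve. Moving from the 3,5-dichlorophenyl group to 3-bromophenyl gives a 5.0-fold higher number from compound 3 to compound 4 (0.70 log units; beyond the scatter), and this shows that a heavier single halogen does not recover what compound 3 gains over compound 1, which points to the 3,5-dichlorophenyl group as a whole as the source of that gain among these compounds, while the move from 2-fluorophenyl gives a 2.9-fold lower number from compound 2 to compound 4 (0.46 log units; beyond the scatter) and places the 3-bromophenyl amide clear of the 2-fluorophenyl one. Nothing measured here accounts for why these aromatic groups differ.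

Still open, as far as these compounds go, is whether the gain depends on having two halogens or on chlorine specifically, a question that a 3,5-dibromophenyl amide would address directly. It is also unknown whether halogen is needed at all on this ring, and a 3-methoxyphenyl or 3,5-dimethylphenyl group on the same carbonyl carbon would test that.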